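Stereochemical definition at the ring carbon of compound 2

This account rests on a few compounds, and the source may have more. Where it says the series, first, only, none or still open, it means among the compounds named here.

Two compounds of this series carry a number in an assay on isolated protein for inhibition of leukotriene B4 receptor 1 (Homo sapiens); a lower number here means a stronger inhibitor, a higher number a weaker inhibitor. Compound 1 `CCCc1c(OCCCOc2ccc(C(=O)N(C)C)c(OC)c2CCC)ccc2c1OC(C(=O)O)CC2` gives 0.15 nM in this assay. Among the measured compounds shown here, compound 2 `CCCc1c(OCCCOc2ccc(C(=O)NC)c(OC)c2CC2CC2)ccc2c1O[C@H](CCC(=O)O)CC2` gives 14.5 nM in this assay, the higher of the two numbers; compound 1 is its nearest neighbour, and the gap between them lies beyond the scatter, but the two structures differ in several places, so no single step between them can be read.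

Compound 3 `CCCc1c(OCCCOc2ccc(C(=O)NC)c(OC)c2CC2CC2)ccc2c1OC(CCC(=O)O)CC2` is the next member. It differs from compound 2 as follows: the two compounds have the same atoms and bonds; at least one stereo element is drawn with a configuration in one of them and without one in the other: 1 of 1 stereo elements differ; a stereocentre at a saturated ring carbon is drawn S in compound 2 and without a configuration in compound 3. For the measured compounds named here, no step of this kind exists among the measured compounds, so its size is unknown here. A drawing without a configuration may stand for a mixture at that centre, and the value of such a mixture depends on which configuration carries the activity; the number for compound 3 could therefore sit either side of that for compound 2, and the wide spread of the two measured values leaves the direction open.

Compound 3 is expected to give about 6 nM in this assay, within 0.5 nM to 40 nM; the step from compound 2 is estimated at a 2.4-fold lower number from compound 2 to compound 3 (0.38 log units; beyond the scatter).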

Compound 3, half-maximal inhibitory concentration: 10.9 nM
Compound 3: middle estimate off by 1.8-fold (0.26 log units), on the low side; the range from low to high includes it.
By their numbers in this assay, from the lowest: compound 1; then compounds 3 and 2 (each within the scatter of the next).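

Among the compounds shown here, compound 2 and compound 3 provide the first readable step in this assay: a 1.3-fold lower number from compound 2 to compound 3 (0.12 log units; within the scatter). For the compounds shown here, this step isolates the stereocentre at the saturated ring carbon, and the S drawing cannot be separated from the drawing without a configuration in this assay, as the only difference between the pair is: the fact that one of compounds 2 and 3 is drawn with a defined configuration and the other without, at the place where they differ Since a drawing without a configuration may stand for a mixture at that centre, this result does not show that the centre is without influence on the number, only that these two drawings read alike here.

Going by these compounds, the value of a compound drawn R at this ring carbon stays open, and with it the question of which configuration, if either, carries the activity. On these data alone, compound 1 differs from compound 2 and compound 3 in several places, so the steps from it cannot be read, and the effect of replacing the carboxylic acid at the end of the chain with a tetrazole also stays open.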